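A Hydroxyl Added to an Inactive Glycoside Ester

The source may hold more compounds than are shown below. What is called first, only, known or untested is meant among the compounds shown, and "the series" means these compounds.

Compound 1 `C[C@]1(O)C[C@@H](OC(=O)/C=C/c2ccccc2)[C@@H]2C=CO[C@@H](O[C@@H]3O[C@H](CO)[C@@H](O)[C@H](O)[C@H]3O)[C@@H]21`: > 10000 nM
Compound 2 `COc1cc([C@@H]2Oc3c(O)cc(/C=C/C(=O)O[C@@H]4C[C@](C)(O)[C@H]5[C@H](O[C@@H]6O[C@H](CO)[C@@H](O)[C@H](O)[C@H]6O)OC=C[C@H]54)cc3[C@H]2CO)ccc1O`: > 10000 nM
Compound 3 `CC(/C=C/[C@@]1(O)C(C)(C)CCC[C@@]1(C)O)=C\C(=O)O[C@@H]1C[C@](C)(O)[C@H]2[C@H](O[C@@H]3O[C@H](CO)[C@@H](O)[C@H](O)[C@H]3O)OC=C[C@H]21`: > 10000 nM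

In a functional assay on A549 cells (Homo sapiens) for cytotoxicity, read by MTT assay, with a stated time of 4 days (a lower number here means a stronger inhibitor, a higher number a weaker inhibitor), compound 1 gives > 10000 nM, which is a limit of the assay rather than a number. Compound 2 gives > 10000 nM, again only a limit. Compound 3 likewise gives > 10000 nM, a limit and not a measured value. Compound 3 therefore stands exactly where every compound of the set stands: at the limit of > 10000 nM in this assay, at which 3 of the 3 values shown sit. Within the data shown here, no two of the measured compounds differ in a single place, so no measured step between them exists, and the three readings show nothing beyond a shared absence of cytotoxicity within the tested range.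

Compound 4 `CC(/C=C/[C@@]1(O)C(C)(C)CC[C@@H](O)[C@@]1(C)O)=C\C(=O)O[C@@H]1C[C@](C)(O)[C@H]2[C@H](O[C@@H]3O[C@H](CO)[C@@H](O)[C@H](O)[C@H]3O)OC=C[C@H]21` is the one not yet measured. It differs from compound 3 by hydroxy in place of hydrogen on a saturated ring carbon. Given that compound 3 sits at > 10000 nM, the step that the limit leaves unreadable from compound 3 to compound 4 is expected to be none beyond the scatter. Compound 4 is expected to give about 15000 nM, between 7000 nM and 60000 nM, and most probably to be reported again only as a limit.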

Compound 4, half-maximal inhibitory concentration: > 10000 nM
Compound 4 gave a limit, no number; the forecaster's own chance of this, stated with the estimate: 85%; the middle value does not contradict the limit.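

Compound 3 and compound 4 both give only a limit and not a number, and no step from one to the other can be read in this assay: the limit of > 10000 nM in this assay, at which 4 of the 4 values shown sit.

The compounds shown leave open whether hydroxy in place of hydrogen on a saturated ring carbon changes the cytotoxicity at all.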